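Shrinking the Ether Substituent to Pyridin-3-yl

The compounds below may be only part of what the source reports. "The series", "measured", "known", "first", "only" and "open" are said of these compounds alone.

Going by the values given here, in a functional assay for inhibition, with Homo sapiens as the target (a lower number here means a stronger inhibitor, a higher number a weaker inhibitor), compound 1 `CC(C)(C)Sc1c(CC(C)(C)C(=O)O)n(Cc2ccc(Cl)cc2)c2ccc(OCc3ccc4cnccc4n3)cc12` gives 3 nM and compound 2 `Cc1nc2ccc(COc3ccc4c(c3)c(SC(C)(C)C)c(CC(C)(C)C(=O)O)n4Cc3ccc(Cl)cc3)cc2s1` gives 6 nM, so compound 2 stands within the scatter of the only other measured number. Among the compounds with values here, the one measured step, a 2.0-fold higher number from compound 1 to compound 2 (0.30 log units; within the scatter), exchanges one aromatic group for another of equal heavy-atom count on the same saturated chain carbon. Compound 3 `CC(C)(C)Sc1c(CC(C)(C)C(=O)O)n(Cc2ccc(Cl)cc2)c2ccc(OCc3cccnc3)cc12` departs from compound 2 differently: pyridin-3-yl in place of 2-methyl-1,3-benzothiazol-6-yl on a saturated chain carbon bound to an oxygen on an aromatic ring. Here the heavy-atom count falls, and the five-membered aromatic ring with 2 hetero atoms is lost. Within the data shown here, no measured step shows what such a reduction does, so the step within the scatter offers only weak guidance. A moderately higher number is expected, an estimated 2.5-fold higher number from compound 2 to compound 3 (0.40 log units; beyond the scatter). The estimate for compound 3 is 15 nM, with an expected range of 4 nM to 60 nM.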

Compound 3, half-maximal inhibitory concentration: 8 nM
Compound 3: the middle estimate sits 1.9-fold (0.27 log units) above what was measured, and the stated range covers the measured number.
By their numbers in this assay, from the lowest: compounds 1, 2 and 3 (each within the scatter of the next, the first and the last beyond it).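

At the saturated chain carbon bound to an oxygen on an aromatic ring, a single pyridin-3-yl ring with fewer heavy atoms can replace the two-ring 2-methyl-1,3-benzothiazol-6-yl group, and in this assay this gives a 1.3-fold higher number from compound 2 to compound 3 (0.12 log units; within the scatter). Measured against the other two-ring group, the same kind of reduction gives a 2.7-fold higher number from compound 1 to compound 3 (0.43 log units; beyond the scatter), the only step among these compounds that lies beyond the scatter, and it is modest, so a single aromatic ring at this place still leaves compound 3 at a low number. Nothing available explains these differences.

The compounds shown leave open whether an aromatic ring is needed on this carbon at all. A morpholine or cyclohexyl group there, or a plain phenyl ring without the ring nitrogen, would begin to answer that.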